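Trimming the Hexyl Chain to Cyclopropyl

The source may report more compounds than this note shows. Statements on the series, on what has been measured and on what is new or still open speak of the compounds shown alone.

Measured compounds in a functional assay on SW-620 cells (Homo sapiens) for antiproliferative activity, read by MTT assay, with a stated time of 72 h; on this read-out lower numbers stand for stronger inhibition and higher numbers for weaker inhibition:
compound 1 `CCCCCCc1cc2cn(Cc3cn(Cc4ccccc4)nn3)c(=O)nc2o1` gives 93500 nM
compound 2 `CCCCCCC#Cc1c(CCCCCC)oc2nc(=O)n(Cc3cn(Cc4ccccc4)nn3)cc12` gives 32600 nM
compound 3 `CCCCCc1ccc(C#Cc2c(-c3ccc(CCCCC)cc3)oc3nc(=O)n(Cc4cn(-c5ccc(Cl)cc5)nn4)cc23)cc1` gives only a limit, > 100000 nM

Among the two numbers reported, compound 1 holds the highest, so it is the weaker of the two inhibitors in this assay. The nearest number belongs to compound 2, reached by a 2.9-fold lower number from compound 1 to compound 2 (0.46 log units; beyond the scatter), a modest step that places oct-1-yn-1-yl in place of hydrogen on an aromatic carbon. For compound 3 this assay reports no number but a limit, > 100000 nM, and the limit of > 100000 nM in this assay, at which 1 of the 3 values shown sits, describes where that value sits.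

Compound 4 `O=c1nc2oc(C3CC3)cc2cn1Cc1cn(Cc2ccccc2)nn1` has not yet been measured. It differs from compound 1 in one place: cyclopropyl in place of hexyl on an aromatic carbon. Among the measured compounds shown here, the single measured step concerns a different position and a different kind of change, so no measured step bears directly on this exchange. With nothing to point one way or the other, the expectation is a step of no meaningful size beyond the scatter. The step that this expectation means is a 1.3-fold higher number from compound 1 to compound 4 (0.11 log units; within the scatter). Compound 4 is therefore estimated at 120000 nM, with a range from 40000 nM to 350000 nM, and a real chance that this assay returns only a limit.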

Compound 4, half-maximal inhibitory concentration: 54700 nM
Compound 4: the middle estimate sits 2.2-fold (0.34 log units) above what was measured; measured number inside the range.
By their numbers in this assay, from the lowest: compounds 2, 4 and 1 (each within the scatter of the next, the first and the last beyond it). At a limit, above all of these: compound 3.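

In this assay, among the compounds shown here, placing cyclopropyl in place of hexyl on the aromatic carbon next to the ring oxygen gives a 1.7-fold lower number from compound 1 to compound 4 (0.23 log units; within the scatter), the first measured change at this position. The hexyl chain, with 6 heavy atoms and no ring, can thus give way to a three-membered carbon ring with 3 heavy atoms without any change in the number that stands beyond the scatter, so the full hexyl chain is not needed here to hold the antiproliferative read-out at this level. The data offered here give no cause for this outcome.

From the compounds shown here alone, what remains open is whether this position would respond to a group of another kind, such as an amine or a carboxylic acid, or to a chain longer than hexyl, since hexyl and cyclopropyl are both hydrocarbon groups without hydrogen-bond donors or acceptors. Going by these compounds, it is also open whether oct-1-yn-1-yl, which was tested only with hexyl at this position among the single-place steps, would give a comparable step with cyclopropyl there.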